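A few compounds are considered here, and "the series" means these few. Any claim that something is new, unique, unknown or untested is made for them only; others in the source may bear on it.

Permeability in an ADME assay for permeability, using PAMPA, with a stated time of 30 min, at pH 7.4 (a higher number here means that the compound crosses the layer faster, a lower number that the compound crosses the layer more slowly), measured compounds:

compound 1 `CN(C)c1cccc(Oc2ccc3c(NCCCNCc4ccco4)ccnc3c2)c1`: 317 10^-6 cm/s
compound 2 `Fc1ccc(Oc2ccc3c(NCCCNCc4ccco4)ccnc3c2)cc1`: 317 10^-6 cm/s
compound 3 `COc1cccc(CNCCCNc2ccnc3cc(Oc4cccc(N(C)C)c4)ccc23)c1O`: 317 10^-6 cm/s

Compound 1 and compound 2 differ only by 4-fluorophenyl in place of 3-(dimethylamino)phenyl on an oxygen on an aromatic ring, and in this assay this gives no change at the digits printed from compound 1 to compound 2 (within the scatter). Compound 3 carries a different core than compound 1, the difference being (2-hydroxy-3-methoxyphenyl in place of furan-2-yl on a saturated chain carbon bound to an amine nitrogen); in this assay the step is no change at the digits printed from compound 1 to compound 3 (within the scatter). Within the data shown here, all three measured values thus sit at the same level, and no compound can be set apart from the others.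

Compound 4 `COc1cccc(CNCCCNc2ccnc3cc(Oc4ccc(F)cc4)ccc23)c1O` has not yet been measured in this assay. It differs from compound 3 by 4-fluorophenyl in place of 3-(dimethylamino)phenyl on an oxygen on an aromatic ring, which is the same change as that from compound 1 to compound 2, made on the same place. Because the earlier step of no change at the digits printed from compound 1 to compound 2 (within the scatter) was flat, the step in this assay for compound 4 is expected to be no change at the digits printed from compound 3 to compound 4 (within the scatter). Compound 4 is therefore estimated at 317 10^-6 cm/s, with an expected range from 200 10^-6 cm/s to 400 10^-6 cm/s.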

Compound 4, apparent permeability: 317 10^-6 cm/s
Estimate against measurement, compound 4: no gap at the digits printed; the measured number falls inside the stated range.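

In this assay, 4-fluorophenyl in place of 3-(dimethylamino)phenyl on an oxygen on an aromatic ring gives no change at the digits printed from compound 3 to compound 4 (within the scatter), which matches the earlier step on the core of compound 1: the same change on two cores in this assay, no change at the digits printed (within the scatter) from compound 1 to compound 2 and no change at the digits printed (within the scatter) from compound 3 to compound 4, 1.0-fold (0.00 log units) apart, within the scatter of two such steps

The second change, 2-hydroxy-3-methoxyphenyl in place of furan-2-yl on a saturated chain carbon bound to an amine nitrogen, gives no change at the digits printed from compound 2 to compound 4 (within the scatter), which again matches its earlier step: the same change on two cores in this assay, no change at the digits printed (within the scatter) from compound 1 to compound 3 and no change at the digits printed (within the scatter) from compound 2 to compound 4, 1.0-fold (0.00 log units) apart, within the scatter of two such steps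

Among these compounds, this shows only that two flat steps stay flat across these cores; with no step of any size among the four compounds, it does not show that a change with a measurable effect would carry over from one core to another.

Still open, from the compounds shown here alone, is whether any other group would leave the level shared by all four compounds. A carboxylic acid on the aromatic ring bound through the oxygen, or a longer chain bearing the amine nitrogen, would test this in this assay.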